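The compounds below may be only part of what the source reports. "The series", "measured", "known", "first", "only" and "open" are said of these compounds alone.

Compound 1 `COc1ccc(/C=C/C(=O)c2cccc(-c3ccc(F)cc3)c2)cc1`: 5550 nM
Compound 2 `COc1ccc(/C=C/C(=O)c2cccc(-c3cccc(F)c3)c2)cc1OC`: 770 nM

In a functional assay on CNE-2 cells (Homo sapiens) for cytotoxicity, read by sulforhodamine B assay, with a stated time of 48 h (a higher number here means a weaker inhibitor, a lower number a stronger inhibitor), compound 2 gives 770 nM, the lower of the two numbers and so the stronger result. Compound 1 gives 5550 nM, higher than compound 2 by a margin beyond the usual scatter. The next compound to be tested is compound 3 `COc1ccc(/C=C/C(=O)c2cccc(-c3ccc(F)cc3)c2)cc1OC`. It keeps everything in compound 2 except one group, with 4-fluorophenyl in place of 3-fluorophenyl on an aromatic carbon.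

Among the measured compounds shown here, no two measured compounds differ in one place only, so the data give no direct measure of what this exchange does. Compound 1, which also carries a 4-fluorophenyl, gives 5550 nM, and this tilts the expectation slightly upward from compound 2. A modest rise in this assay is therefore expected, perhaps not much beyond the scatter, and the estimated change is a 1.7-fold higher number from compound 2 to compound 3 (0.23 log units; within the scatter). For compound 3 the estimated value is 1300 nM, with an expected range from 400 nM to 4500 nM.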

Compound 3, half-maximal inhibitory concentration: 5550 nM
Beside the measured number, compound 3's estimate is 4.3-fold (0.63 log units) below it; measured number outside the range, above it.
By their numbers in this assay, from the lowest: compound 2; then compounds 1 and 3 (each within the scatter of the next).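

In this assay, among the compounds shown here, the exchange of 3-fluorophenyl for 4-fluorophenyl on an aromatic carbon, meta to a large group, gives a 7.2-fold higher number from compound 2 to compound 3 (0.86 log units; beyond the scatter), the first reading of this change on its own. The two groups have the same atoms joined differently, so at this position the assay separates two fluorophenyl groups that differ only in where the fluorine sits. With 4-fluorophenyl in place, methoxy in place of hydrogen on an aromatic carbon gives no change at the digits printed from compound 1 to compound 3 (within the scatter), so this added methoxy makes no difference beyond the scatter in this pair. Nothing measured alongside these numbers accounts for the step between the two fluorophenyl groups.

Whether the methoxy step would read the same with 3-fluorophenyl in place remains open, as the compounds shown give that step only with 4-fluorophenyl. Also open, on these data alone, is what an amine or a carboxylic acid would do in place of the fluorine on that ring, and whether any such group would give a lower number than the 3-fluorophenyl of compound 2.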